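The compounds below may be only part of what the source reports. "The series", "measured", "known", "first", "only" and "open" are said of these compounds alone.

Working notes on the series.

Of the compounds shown here, two have been measured so far. In an assay on cells for inhibition of Indoleamine 2,3-dioxygenase 1 (Homo sapiens), read by HPLC, with a stated time of 20 min (on this read-out lower numbers stand for stronger inhibition and higher numbers for weaker inhibition), compound 1 `Nc1ccc(Cl)cc1-c1cnn[nH]1` gives 1500 nM, and compound 2 `Clc1cccc(-c2nnc[nH]2)c1` gives 31000 nM. Compound 2 stands at the highest of the two numbers; its nearest neighbour is compound 1, whose number is lower by a margin that lies beyond the usual scatter. Compound 1 and compound 2 differ in more than one place. Going by the values given here, no single step between them is counted.

The next compound follows compound 2 with one change: compound 3 `Nc1ccc(Cl)cc1-c1nnc[nH]1` differs from compound 2 by amino in place of hydrogen on an aromatic carbon. Among the compounds with values here, no measured pair in this set shows this exact change on this core, so the size of the step is open. Compound 1 carries the same amino and chloro pattern on its six-membered ring and sits at 1500 nM, which points toward a lower number for compound 3 than for compound 2, though the core of compound 1 is not the same.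

On that basis compound 3 is expected to show 3500 nM in this assay, with a range from 800 nM to 15000 nM, a step from compound 2 to compound 3 of an 8.9-fold lower number from compound 2 to compound 3 (0.95 log units; beyond the scatter) estimated as a clear drop.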

Compound 3, half-maximal inhibitory concentration: 35 nM
Beside the measured number, compound 3's estimate is 100-fold (2.00 log units) above it; measured number outside the range, below it.
By their numbers in this assay, from the lowest: compound 3; then compound 1; then compound 2.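

In this assay, amino in place of hydrogen on an aromatic carbon, ortho to a group of 5 heavy atoms and para to a chloro group, gives an 890-fold lower number from compound 2 to compound 3 (2.95 log units; beyond the scatter). Going by these compounds alone, this is the first single-change step, and it shows that this position on the six-membered aromatic ring of carbon only is highly sensitive: the entry of one nitrogen, counted as 1 hydrogen-bond donor and 1 hydrogen-bond acceptor, moves the number by a large margin, well beyond the usual scatter. Nothing measured here accounts for the size of this step.

The compounds shown leave open whether a methylamino, a hydroxyl or a methyl group at the same place would give a step of similar size, or whether the amino group stands alone in this respect. Also open, from the compounds shown here alone, is how far the number of compound 3 depends on the chloro group, which could be tested by putting a fluoro group or a nitrile in its place on the same core.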